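The source may report more compounds than this note shows. Statements on the series, on what has been measured and on what is new or still open speak of the compounds shown alone.

Numbers so far in a functional assay on SW-620 cells (Homo sapiens) for inhibition; on this read-out lower numbers stand for stronger inhibition of growth and higher numbers for weaker inhibition of growth:
compound 1 `COc1cc(/C=C/C(=O)c2cccc(-n3cc(-c4ccc(Cl)cc4)[nH]c3=O)c2)cc(OC)c1OC` gives 1750 nM
compound 2 `COc1cc(/C=C/C(=O)c2cccc(-n3cc(-c4ccccc4)[nH]c3=O)c2)ccc1O` gives 2290 nM
compound 3 `O=C(/C=C/c1cccc(O)c1)c1cccc(-n2cc(-c3ccccc3)[nH]c2=O)c1` gives 2410 nM

Compound 1 stands closest to compound 2 and somewhat further from compound 3, but both gaps lie within the usual scatter, so the three compounds are not separated on this read-out. Within the data shown here, the one measured step, a 1.1-fold higher number from compound 2 to compound 3 (0.02 log units; within the scatter), concerns the other end of the shared core and does not bear on the change now considered.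

Compound 4 `COc1cc(/C=C/C(=O)c2cccc(-n3cc(-c4ccccc4)[nH]c3=O)c2)cc(OC)c1OC` differs from compound 1 by hydrogen in place of chloro on an aromatic carbon. Among the measured compounds shown here, no measured pair addresses removal of chloro on this ring, so nothing in the data points to a shift in either direction; the expectation for a 1.1-fold higher number from compound 1 to compound 4 (0.06 log units; within the scatter) is a step that stays within the scatter. Compound 4 is therefore estimated at 2000 nM, within 800 nM to 5000 nM.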

Compound 4, concentration for 50% growth inhibition: 390 nM
Compound 4: middle estimate off by 5.1-fold (0.71 log units), on the high side; the measured number lies below the stated range.
By their numbers in this assay, from the lowest: compound 4; then compounds 1, 2 and 3 (each within the scatter of the next).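

In this assay, among these compounds, the change from 4-chlorophenyl to phenyl gives the first step that passes the scatter (a 4.5-fold lower number from compound 1 to compound 4 (0.65 log units; beyond the scatter)). Among the compounds shown here, the position para to a large group thus affects this read-out, which the earlier compounds, all within the scatter of one another, could not show. Nothing available accounts for the size of this step.

Going by these compounds, only chloro and hydrogen are seen at this position, so the effect of fluoro, methoxy or an amine there remains open. Also open, on these data alone, is whether the step holds with the 3-hydroxyphenyl group of compound 3 or the 4-hydroxy-3-methoxyphenyl group of compound 2.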